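This account rests on a few compounds, and the source may have more. Where it says the series, first, only, none or still open, it means among the compounds named here.

The series shares one core, seen in compound 1 `COC1=C[C@H](O)[C@H](C/C=C(\C)CC/C=C(\C)CCC=C(C)C)[C@@H](C)C1=O` and its relatives compound 2 `COC1=C[C@H](O)[C@H](C/C=C(\C)CC/C=C(\C)C[C@@H]2C[C@@H](C)C(=O)O2)[C@@H](C)C1=O` and compound 3 `COC1=C(OC)[C@H](O)[C@H](C/C=C(\C)CC/C=C(\C)C[C@H](O)/C=C(\C)CO)[C@@H](C)C1=O`, all tested in a functional assay on PC-3 cells (Homo sapiens) for inhibition, read by sulforhodamine B assay, with a stated time of 48 h; a higher number here means a weaker inhibitor of growth, a lower number a stronger inhibitor of growth. In this assay compound 1 gives only a limit, > 30000 nM. Compound 2 likewise reaches only a limit, > 30000 nM. Compound 3 too shows only a limit, > 30000 nM. Among the measured compounds shown here, the single one-place step among the measured compounds, a step that the two limits leave unreadable from compound 1 to compound 2, therefore cannot be read, and the whole picture rests on (the limit of > 30000 nM in this assay, at which 3 of the 3 values shown sit). Compound 3 thus stands at the same limit as the other two, with no number to set it apart.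

The unmeasured compound 4 `COC1=C[C@H](O)[C@H](C/C=C(\C)CC/C=C(\C)C[C@H](O)/C=C(\C)CO)[C@@H](C)C1=O` differs from compound 3 in one place: hydrogen in place of methoxy on a double-bonded ring carbon, methoxy leaving and hydrogen entering on a double-bonded ring carbon of a six-membered non-aromatic ring of carbon only. For the measured compounds named here, no measured step bears on this change, and the one measured step, being unreadable, gives no size to lean on; so no step beyond the scatter can be expected in this assay in either direction. Compound 4 is therefore expected to sit at or near the same limit, estimated at 40000 nM with a range from 15000 nM to 100000 nM. The step that the limit leaves unreadable from compound 3 to compound 4 is expected to be essentially none.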

Compound 4, concentration for 50% growth inhibition: > 30000 nM
Compound 4 ended at the assay's limit (the forecaster's own chance of this, stated with the estimate: 80%); the middle value does not contradict the limit.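

No new step can be read: the steps joining compound 4 to compound 1, compound 2 and compound 3 all run between limits, so none of them has a size, and the picture in this assay stays as it was: (the limit of > 30000 nM in this assay, at which 4 of the 4 values shown sit). The compounds shown leave open whether any of these changes alters growth inhibition at all.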